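The compounds below may be only part of what the source reports. "The series", "measured", "known", "first", "only" and "open" are said of these compounds alone.

Three compounds share one core, and they differ only in the group carried on the aromatic carbon of the five-membered ring. Compound 1 `COc1cc(C(=O)c2sc(-c3ccc(C)cc3)cc2N)cc(OC)c1OC` gives 18 nM in a functional assay on L1210 cells (Mus musculus) for antiproliferative activity (a higher number here means a weaker inhibitor, a lower number a stronger inhibitor), and compound 2 `COc1cc(C(=O)c2sc(-c3ccc(F)cc3)cc2N)cc(OC)c1OC` gives 20 nM there. Compound 3 `CCOc1ccc(-c2cc(N)c(C(=O)c3cc(OC)c(OC)c(OC)c3)s2)cc1` gives 590 nM; this is the highest number of the three, with a 30-fold higher number from compound 2 to compound 3 (1.47 log units; beyond the scatter) and a 33-fold higher number from compound 1 to compound 3 (1.52 log units; beyond the scatter). Between compounds 1 and 2 the step is small, a 1.1-fold higher number from compound 1 to compound 2 (0.05 log units; within the scatter).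

Compound 4 `COc1cc(C(=O)c2sc(-c3ccncc3)cc2N)cc(OC)c1OC` is not yet measured. The change from compound 3 is pyridin-4-yl in place of 4-ethoxyphenyl on an aromatic carbon. Both measured steps into compound 3 bear on it, since each removes the ethoxy group from the same aromatic carbon: both were large, and in each case the number rose when the ethoxy group was present. Among the compounds with values here, compound 4 also lacks the ethoxy group, so a large drop in the number is expected from compound 3, a 15-fold lower number from compound 3 to compound 4 (1.17 log units; beyond the scatter), though no measured step shows a pyridin-4-yl group at this position, and the estimate is therefore less certain than the size of the measured steps. Compound 4 is estimated at 40 nM, with a range from 12 nM to 160 nM.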

Compound 4, half-maximal inhibitory concentration: 1810 nM
Compound 4: middle estimate off by 45-fold (1.66 log units), on the low side; the measured number lies above the stated range.
By their numbers in this assay, from the lowest: compounds 1 and 2 (each within the scatter of the next); then compound 3; then compound 4.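

In this assay the change to pyridin-4-yl gave a 3.1-fold higher number from compound 3 to compound 4 (0.49 log units; beyond the scatter) and so showed that removing the 4-ethoxyphenyl group does not by itself bring a lower number at this aromatic carbon next to the ring sulfur. Measured against the two compounds with a low number, the change is larger still, with a 91-fold higher number from compound 2 to compound 4 (1.96 log units; beyond the scatter) and a 100-fold higher number from compound 1 to compound 4 (2.00 log units; beyond the scatter) for the replacement of 4-fluorophenyl and 4-methylphenyl. The earlier compounds shown here varied only a group carried on a six-membered aromatic ring of carbon only, whereas this result shows that changing that ring itself to one with a hetero atom can also raise the number, here further than the ethoxy group did. Nothing available explains why the pyridin-4-yl group gives this result.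

The compounds shown leave open whether the place of the ring nitrogen matters, as a pyridin-3-yl or pyridin-2-yl group would test. They also leave open how a methoxy group, a longer chain such as propoxy, an amine or a carboxylic acid on the carbon-only ring would compare with the methyl, fluoro and ethoxy groups.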